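Aryl acyl to propanoyl: expected loss of cell potency

The source may report more compounds than this note shows. Statements on the series, on what has been measured and on what is new or still open speak of the compounds shown alone.

Within the data shown here, compound 1 `O=C(Nc1cc(C(F)(F)F)cc(C(F)(F)F)c1)C1CCc2ccccc2N1C(=O)c1ccccc1Cl` carries the only number here in a functional assay on NCI-H23 cells (Homo sapiens) for cytotoxicity, read by sulforhodamine B assay, with a stated time of 72 h; on this read-out lower numbers stand for stronger inhibition of growth and higher numbers for weaker inhibition of growth: compound 1 gives 2080 nM. Compound 2 `O=C(Nc1ccccc1C(F)(F)F)c1ccc2ccccc2n1` is reported in this assay only as a limit, > 90000 nM. Of the two values shown, one therefore sits at the limit of > 90000 nM in this assay, at which 1 of the 2 values shown sits. Compound 3 `CCC(=O)N1c2ccccc2CCC1C(=O)Nc1cc(C(F)(F)F)cc(C(F)(F)F)c1` differs from compound 1 by ethyl in place of 2-chlorophenyl on a carbonyl carbon, the (2-chlorophenyl)carbonyl becoming propanoyl. Among the measured compounds shown here, no measured step of this kind exists in the data; the expectation is a change beyond the scatter towards weaker inhibition of growth, a 4.3-fold higher number from compound 1 to compound 3 (0.64 log units; beyond the scatter). Compound 3 is estimated at 9000 nM, within a range from 2500 nM to 40000 nM.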

Compound 3, concentration for 50% growth inhibition: 7820 nM
Estimate against measurement, compound 3: 1.2-fold (0.06 log units) above; low and high end bracket the measured number.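

In this assay the change from (2-chlorophenyl)carbonyl to propanoyl brings a 3.8-fold higher number from compound 1 to compound 3 (0.58 log units; beyond the scatter) and so gives this position its first measured step. The aromatic ring is not needed for a measured number on this read-out: compound 3 gives 7820 nM and is not a limit. No measurement shown bears on the cause of this step.

Still open, on these data alone, is whether the chlorine or the ring itself carries the step. Plain phenyl, a longer chain such as butanoyl or an acyl group bearing an amine would separate these.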